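Benzamide replaces the diaryl urea: expected cytotoxicity

The source may hold more compounds than are shown below. What is called first, only, known or untested is meant among the compounds shown, and "the series" means these compounds.

Of the compounds shown here, three have been measured in a functional assay on HCT-116 cells (Homo sapiens) for inhibition, read by sulforhodamine B assay, with a stated time of 48 h; on this read-out higher numbers stand for lower toxicity in this test and lower numbers for higher toxicity in this test. Compound 1 `COc1cc(-c2nn(-c3cccc(NC(=O)Nc4ccc(Cl)c(Cl)c4)c3)cc2-c2ccncc2)ccc1Cl` gives only a limit, > 50000 nM. Compound 2 `COc1cc(-c2nn(-c3cccc(NC(=O)Nc4cccc(C(F)(F)F)c4)c3)cc2-c2ccncc2)ccc1Cl` likewise gives only a limit, > 50000 nM. Compound 3 `COc1cc(-c2nn(-c3cccc(NC(=O)Nc4ccc(Cl)c(C(F)(F)F)c4)c3)cc2-c2ccncc2)ccc1Cl` is the sole member with a number, 21500 nM, and so stands alone at the readable end of what has been shown. The remaining two values are covered by the limit of > 50000 nM in this assay, at which 2 of the 3 values shown sit. The step of an at least 2.3-fold lower number from compound 1 to compound 3 (0.36 log units; beyond the scatter) and the step of an at least 2.3-fold lower number from compound 2 to compound 3 (0.36 log units; beyond the scatter) both run toward compound 3, whereas a step that the two limits leave unreadable from compound 1 to compound 2 cannot be read.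

Compound 4 `COc1cc(-c2nn(-c3cccc(NC(=O)c4ccccc4)c3)cc2-c2ccncc2)ccc1Cl` is the untested member. It differs from compound 3 by phenyl in place of (4-chloro-3-(trifluoromethyl)phenyl)amino on a carbonyl carbon, so the carbonyl carbon now carries a phenyl where it carried the (4-chloro-3-(trifluoromethyl)phenyl)amino group. Among the compounds with values here, none of the measured steps alters this part of the molecule in the same way; the two readable ones change only substituents on that group, and each move away from the exact pattern of compound 3 returned the value to the limit. Removing the group entirely is therefore expected to carry compound 4 back toward the limit, a step of a 2.1-fold higher number from compound 3 to compound 4 (0.32 log units; beyond the scatter) in the direction of lower toxicity. The expected value for compound 4 in this assay is 45000 nM, between 15000 nM and 100000 nM, with a real chance that only a limit is recorded.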

Compound 4, concentration lethal to 50% of the cells: > 100000 nM
Compound 4 gave a limit, no number; the forecaster's own chance of this, stated with the estimate: 60%; middle value at least 2.2-fold (0.34 log units) away from the limit.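

In this assay compound 4 gives a limit and not a number: the limit of > 100000 nM in this assay, at which 1 of the 4 values shown sits. Phenyl in place of (4-chloro-3-(trifluoromethyl)phenyl)amino on a carbonyl carbon gives an at least 4.6-fold higher number from compound 3 to compound 4 (0.66 log units; beyond the scatter), so this is the first readable change to the whole group on the carbonyl carbon, whereas the earlier readable steps changed only substituents on the aryl ring of that group. Among the compounds shown, a number appears only with the (4-chloro-3-(trifluoromethyl)phenyl)amino group, while compound 1, compound 2 and compound 4 all end at limits, and the steps from compound 1 and from compound 2 to compound 4 join two limits and cannot be read.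

The change removes both the nitrogen with its hydrogen and the ring substituents, so the compounds shown do not separate these two parts; a 4-chloro-3-(trifluoromethyl)phenyl group set directly on the carbonyl carbon would do so. Also open, on these data alone, is how a benzamide with a substituted ring, such as one carrying a dimethylamino group or a carboxylic acid, would read in this assay.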